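Vinyl for hydroxy on the saturated ring, methylsulfanyl series

The source may report more compounds than this note shows. Statements on the series, on what has been measured and on what is new or still open speak of the compounds shown alone.

Three compounds measured to date in a functional assay on HT-29 cells (Homo sapiens) for inhibition, read by sulforhodamine B assay, with a stated time of 72 h; a lower number here means a stronger inhibitor, a higher number a weaker inhibitor. Compound 1 `C=CC1C(=O)N(c2cc(OC)c(OC)c(OC)c2)C1c1ccc(OC)cc1` gives 10 nM. Compound 2 `COc1ccc(C2C(O)C(=O)N2c2cc(OC)c(OC)c(OC)c2)cc1` gives 12 nM. Compound 3 `COc1cc(N2C(=O)C(O)C2c2ccc(SC)cc2)cc(OC)c1OC` gives 15 nM, which is the highest of the three numbers, but its gaps to compound 2 and to compound 1 both sit within the scatter, so no ordering among the three can be claimed. The two single-change steps recorded so far are small: a 1.2-fold higher number from compound 1 to compound 2 (0.08 log units; within the scatter), and a 1.3-fold higher number from compound 2 to compound 3 (0.10 log units; within the scatter).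

Compound 4 `C=CC1C(=O)N(c2cc(OC)c(OC)c(OC)c2)C1c1ccc(SC)cc1`, not yet measured, differs from compound 3 by vinyl in place of hydroxy on a saturated ring carbon. Within the data shown here, one measured step bears on this exchange directly: the move from compound 1 to compound 2 is the same swap run the other way, on compounds carrying methoxy rather than methylsulfanyl, and there it was a 1.2-fold higher number from compound 1 to compound 2 (0.08 log units; within the scatter). With that step inside the scatter, and the methoxy-to-methylsulfanyl step also inside the scatter, nothing beyond the scatter is expected for compound 4 in this assay in either direction. The estimate for compound 4 is therefore 13 nM, with an expected range from 6 nM to 28 nM. This corresponds to an expected step of a 1.2-fold lower number from compound 3 to compound 4 (0.06 log units; within the scatter).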

Compound 4, half-maximal inhibitory concentration: 113 nM
Compound 4: middle estimate off by 8.7-fold (0.94 log units), on the low side, outside the stated range (above it).
By their numbers in this assay, from the lowest: compounds 1, 2 and 3 (each within the scatter of the next); then compound 4.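

In this assay, vinyl in place of hydroxy on this saturated ring carbon is not a neutral exchange once the 4-(methylsulfanyl)phenyl group is present, giving a 7.5-fold higher number from compound 3 to compound 4 (0.88 log units; beyond the scatter), so its outcome depends on the other place in the molecule: the same change on two cores in this assay, a 1.2-fold higher number (0.08 log units; within the scatter) from compound 1 to compound 2 and a 7.5-fold lower number (0.88 log units; beyond the scatter) from compound 4 to compound 3, 9.0-fold (0.96 log units) apart, beyond the scatter of two such steps

Read from that other place, methylsulfanyl in place of methoxy on an aromatic carbon matters only when vinyl occupies the ring carbon, giving an 11-fold higher number from compound 1 to compound 4 (1.05 log units; beyond the scatter): the same change on two cores in this assay, a 1.3-fold higher number (0.10 log units; within the scatter) from compound 2 to compound 3 and an 11-fold higher number (1.05 log units; beyond the scatter) from compound 1 to compound 4, 9.0-fold (0.96 log units) apart, beyond the scatter of two such steps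

The two changes therefore do not simply add across these four compounds: only compound 4, which combines vinyl with methylsulfanyl, stands apart, while compounds 1, 2 and 3 remain unordered.

Whether the weaker number belongs to vinyl specifically remains open, since the compounds shown do not tell how an ethyl, a methyl, an amino or a methoxy group on this ring carbon would behave in the 4-(methylsulfanyl)phenyl series. On these data alone, the data also give no reason for the combined effect, and whether it extends to other cell lines is unknown.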